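From an Octyl Chain to a Ring-Bearing Group

This account rests on a few compounds, and the source may have more. Where it says the series, first, only, none or still open, it means among the compounds named here.

In a functional assay on cells (T-cell line, Homo sapiens) for inhibition (a higher number here means a weaker inhibitor, a lower number a stronger inhibitor), compound 3 (`CCCCCCCCCN1CCC(COC(c2ccccc2)c2ccccc2)CC1`) gives 700 nM. Compound 2 (`CCCCCCCN1CCC(COC(c2ccccc2)c2ccccc2)CC1`) gives 500 nM, and the step between them, a 1.4-fold higher number from compound 2 to compound 3 (0.15 log units; within the scatter), is too small to separate them. Compound 1 (`Clc1ccc(CCCN2CCC(COC(c3ccccc3)c3ccccc3)CC2)cc1Cl`) gives 2200 nM. Compound 4 (`c1ccc(C(OCC2CCN(CC3CCc4ccccc4C3)CC2)c2ccccc2)cc1`) makes one change to compound 3: 1,2,3,4-tetrahydronaphthalen-2-yl in place of octyl on a saturated chain carbon bound to an amine nitrogen in a ring. For the measured compounds named here, no measured pair contains this exact swap, so the nearest guide is compound 1, whose chain carries 3,4-dichlorophenyl. Replacing that group with butyl gave a 4.4-fold lower number from compound 1 to compound 2 (0.64 log units; beyond the scatter), and replacing it with hexyl gave a 3.1-fold lower number from compound 1 to compound 3 (0.50 log units; beyond the scatter). Read in reverse, these steps suggest that a ring-bearing group may raise the number in this assay. Compound 4 has a different ring group from compound 1, however, so the guide is only approximate and a smaller, modest rise seems the fair expectation. The expected change is a 1.7-fold higher number from compound 3 to compound 4 (0.23 log units; within the scatter). For compound 4, the estimated value is 1200 nM, with an expected range of 450 nM to 3200 nM.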

Compound 4, half-maximal inhibitory concentration: 5600 nM
Compound 4: middle estimate off by 4.7-fold (0.67 log units), on the low side; measured number outside the range, above it.
By their numbers in this assay, from the lowest: compounds 2 and 3 (each within the scatter of the next); then compound 1; then compound 4.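

Placing the 1,2,3,4-tetrahydronaphthalen-2-yl group on this saturated chain carbon carries a clear penalty in this assay, with an 8.0-fold higher number from compound 3 to compound 4 (0.90 log units; beyond the scatter) and an 11-fold higher number from compound 2 to compound 4 (1.05 log units; beyond the scatter) among the steps from the open chains. The step to the other ring-bearing group, a 2.5-fold higher number from compound 1 to compound 4 (0.41 log units; beyond the scatter) on replacing 2-(3,4-dichlorophenyl)ethyl, shows that ring-bearing groups are not interchangeable at this position. Across these four compounds, both ring-bearing groups give higher numbers than both open chains, and none goes against this, although two examples of each type make a thin basis for a pattern.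

Nothing measured here explains the size of these steps. Going by these compounds, it remains open whether a simple benzyl group, a cyclohexylmethyl group or an unsubstituted 3-phenylpropyl group would behave like the open chains or like the ring-bearing groups at this position.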